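The compounds below may be only part of what the source reports. "The series", "measured", "known", "first", "only" and "open" are said of these compounds alone.

Compound 1 `CCN(CC)CCCOc1cc2ncnc(Nc3ccc(C#N)cc3)c2cc1OC` gives 68900 nM in a functional assay on DU-145 cells (Homo sapiens) for antiproliferative activity, read by MTT assay, with a stated time of 72 h; a higher number here means a weaker inhibitor, a lower number a stronger inhibitor.
Compound 2 `COc1cc2c(Nc3ccc(C#N)cc3)ncnc2cc1OCCCN1CCC(O)CC1` gives 74900 nM in this assay.

Of these two numbers, compound 1 has the lower one, and its nearest neighbour is compound 2: a 1.1-fold higher number from compound 1 to compound 2 (0.04 log units; within the scatter). Compound 3 `CCN1CCN(CCCOc2cc3ncnc(Nc4ccc(C#N)cc4)c3cc2OC)CC1` differs from compound 1 in a single place: 4-ethylpiperazin-1-yl in place of diethylamino on a saturated chain carbon, three bonds along the chain from an oxygen on an aromatic ring. Among the measured compounds shown here, only one measured step bears on this change, the one from compound 1 to compound 2, in which a six-membered ring amine also replaced diethylamino on a saturated chain carbon, three bonds along the chain from an oxygen on an aromatic ring, and it gave a 1.1-fold higher number from compound 1 to compound 2 (0.04 log units; within the scatter). Since that step stayed within the scatter, no step beyond the scatter is expected for compound 3 in this assay either. Compound 3 is therefore estimated at 70000 nM, with a range from 35000 nM to 140000 nM. The expected step is a 1.0-fold higher number from compound 1 to compound 3 (0.01 log units; within the scatter).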

Compound 3, half-maximal inhibitory concentration: 34400 nM
Estimate against measurement, compound 3: 2.0-fold (0.31 log units) above; the measured number lies below the stated range.
By their numbers in this assay, from the lowest: compounds 3, 1 and 2 (each within the scatter of the next, the first and the last beyond it).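

At this position, this assay now shows its first step beyond the scatter: swapping 4-hydroxypiperidin-1-yl for 4-ethylpiperazin-1-yl gives a 2.2-fold lower number from compound 2 to compound 3 (0.34 log units; beyond the scatter), a modest change. Replacing diethylamino with 4-ethylpiperazin-1-yl gives a 2.0-fold lower number from compound 1 to compound 3 (0.30 log units; within the scatter), so this step stays within the scatter. The position therefore shows some sensitivity to which ring amine it carries, but the three compounds do not show that a ring alone changes the number, since neither ring step from diethylamino goes beyond the scatter.

On these data alone, how a morpholine ring, an unsubstituted piperazine or a longer chain would behave at this position remains open. Nothing available here explains the gap between the two ring amines.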